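The compounds below may be only part of what the source reports. "The series", "measured", "known", "first", "only" and "open" are said of these compounds alone.

In a functional assay on MIA PaCa-2 cells (Homo sapiens) for antiproliferative activity, read by MTT assay, with a stated time of 48 h (a higher number here means a weaker inhibitor, a lower number a stronger inhibitor), compound 1 `COc1ccc(Cc2nc(N)n(CC(=O)Nc3ccccc3)c2-c2ccccc2Br)cc1` gives 3200 nM. Compound 2 `CC(C)(C)c1ccc(Cc2nc(N)n(CC(=O)Nc3ccccc3)c2-c2ccccc2Br)cc1` carries tert-butyl in place of methoxy on an aromatic carbon relative to compound 1, and in this assay compound 2 gives 4900 nM; this change made a step of a 1.5-fold higher number from compound 1 to compound 2 (0.19 log units; within the scatter). Compound 3 `COc1ccc(Cc2nc(N)n(CC(=O)Nc3ccc(C)cc3)c2-c2ccccc2Br)cc1` shares its core with the unmeasured compound 4 `Cc1ccc(NC(=O)Cn2c(N)nc(Cc3ccc(C(C)(C)C)cc3)c2-c2ccccc2Br)cc1`, and these two cores differ from those of compound 1 and compound 2 by methyl in place of hydrogen on an aromatic carbon, a change that in this assay gave a 1.6-fold higher number from compound 1 to compound 3 (0.21 log units; within the scatter). In this assay compound 3 gives 5200 nM, and of the three measured numbers it is the highest, though its distance to compound 2 and to compound 1 lies within the scatter. Compound 4 differs from compound 3 by tert-butyl in place of methoxy on an aromatic carbon, the same change already seen from compound 1 to compound 2, at a place described in the same words. The step from compound 3 to compound 4 is therefore expected to be about a 1.5-fold higher number from compound 3 to compound 4 (0.18 log units; within the scatter), with room for scatter because a 1.5-fold higher number from compound 1 to compound 2 (0.19 log units; within the scatter) was itself small. On that basis compound 4 is estimated at 7800 nM in this assay, likely between 3500 nM and 17000 nM.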

Compound 4, half-maximal inhibitory concentration: 3400 nM
Estimate against measurement, compound 4: 2.3-fold (0.36 log units) above, and the stated range ends above it.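

In this assay, tert-butyl in place of methoxy gave a 1.5-fold lower number from compound 3 to compound 4 (0.18 log units; within the scatter) on the methyl-bearing core, and this step stays within the scatter of the earlier one on the core of compound 1: the same change on two cores in this assay, a 1.5-fold higher number (0.19 log units; within the scatter) from compound 1 to compound 2 and a 1.5-fold lower number (0.18 log units; within the scatter) from compound 3 to compound 4, 2.3-fold (0.37 log units) apart, within the scatter of two such steps

Methyl in place of hydrogen, now with tert-butyl on the other aromatic ring, gave a 1.4-fold lower number from compound 2 to compound 4 (0.16 log units; within the scatter), and it too stays within the scatter of its earlier step: the same change on two cores in this assay, a 1.6-fold higher number (0.21 log units; within the scatter) from compound 1 to compound 3 and a 1.4-fold lower number (0.16 log units; within the scatter) from compound 2 to compound 4, 2.3-fold (0.37 log units) apart, within the scatter of two such steps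

These four compounds therefore show no difference between the two cores beyond the scatter, but they do not show that either change has a real effect on any core, or that such an effect would carry reliably from one core to another.

From the compounds shown here alone, it remains open whether an amine or a carboxylic acid in place of the methoxy, or a longer chain in place of the methyl of compound 3, would give steps large enough to compare across cores. Going by these compounds, whether the two changes behave alike in other cell lines also remains open.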